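This account rests on a few compounds, and the source may have more. Where it says the series, first, only, none or still open, it means among the compounds named here.

Measured compounds, a functional assay on A549 cells (Homo sapiens) for antiproliferative activity, read by sulforhodamine B assay, with a stated time of 3 days; a lower number here means a stronger inhibitor of growth, a higher number a weaker inhibitor of growth:
- compound 1, `O=C(Nc1ccccn1)c1cccc(Nc2ncc(F)c(Nc3ccc(F)cc3)n2)c1`: 15300 nM
- compound 2, `O=C(Nc1ccc(C(F)(F)F)cc1)c1cccc(Nc2ncc(F)c(Nc3ccc(F)cc3)n2)c1`: > 10000 nM, a limit of the assay rather than a number

Going by the values given here, compound 1 is the only compound of the pair with a number in this assay; compound 2 sits at the limit of this assay, (the limit of > 10000 nM in this assay, at which 1 of the 2 values shown sits). The step from the amide-type nitrogen bearing pyridin-2-yl to the one bearing 4-(trifluoromethyl)phenyl, a step that the limit leaves unreadable from compound 1 to compound 2, therefore has no readable size.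

Compound 3, `O=C(Nc1cc(Cl)cc(Cl)c1)c1cccc(Nc2ncc(F)c(Nc3ccc(F)cc3)n2)c1`, is not yet measured. It differs from compound 1 at the same amide-type nitrogen: 3,5-dichlorophenyl in place of pyridin-2-yl on an amide-type nitrogen. Among the compounds with values here, the one measured step at this position is the one from compound 1 to compound 2, and it is unreadable, so there is no measured step from which a size or direction can be taken. Compound 1 already sits at a weak value, and the second carbon-only ring on this nitrogen gave a limit, so a limit is a real possibility for compound 3 as well. The expectation for compound 3 is a growth-inhibition concentration near that of compound 1 or weaker, a step of a 1.3-fold higher number from compound 1 to compound 3 (0.12 log units; within the scatter), giving an estimated 20000 nM with a range from 6000 nM to 60000 nM.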

Compound 3, concentration for 50% growth inhibition: 17500 nM
Estimate against measurement, compound 3: 1.1-fold (0.06 log units) above, within the range that was stated.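

In this assay the amide-type nitrogen now has its first readable step, a 1.1-fold higher number from compound 1 to compound 3 (0.06 log units; within the scatter), for 3,5-dichlorophenyl in place of pyridin-2-yl. In this one pair, a ring with 1 hetero atom and 1 hydrogen-bond acceptor gives way to a carbon-only ring with 0 hydrogen-bond acceptors and 2 chlorine atoms, and the value does not move beyond the scatter, so the ring nitrogen of pyridin-2-yl shows no measurable contribution here. Compound 2 carries a limit of the assay rather than a number, so the steps that touch it cannot be read: the limit of > 10000 nM in this assay, at which 1 of the 3 values shown sits.

The compounds shown leave open whether any other kind of group on this nitrogen, such as a short alkyl chain or a phenyl ring carrying an amine or a carboxylic acid, would move the value beyond the scatter. They also leave open where compound 2 truly stands against compound 1 and compound 3, and so whether 4-(trifluoromethyl)phenyl differs at all from the other two groups.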